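Aryl variation at the saturated ring carbon of the shared core

The source may report more compounds than this note shows. Statements on the series, on what has been measured and on what is new or still open speak of the compounds shown alone.

Measured compounds:
- compound 1, `N#CC1=C(N)N(c2ccc(S(N)(=O)=O)cc2)C2=C(C(=O)CCC2)C1c1cccc([N+](=O)[O-])c1`: 71%
- compound 2, `N#CC1=C(N)N(c2ccc(S(N)(=O)=O)cc2)C2=C(C(=O)CCC2)C1c1ccc(Cl)cc1Cl`: 95%

In a functional assay on Ehrlich cells (Mus musculus) for antiproliferative activity, read by trypan blue exclusion, with a stated time of 2 h, tested at 100 ug/mL (a lower number here means a weaker effect, a higher number a stronger effect of the compound at the concentration tested), compound 1 gives 71% and compound 2 gives 95%. Among the measured compounds shown here, the only step within the measured pair is a number 24 percentage points higher from compound 1 to compound 2 (beyond the scatter), so compound 2 stands highest of the two numbers, with compound 1 the nearest and lower beyond the scatter. Compound 3, `COc1ccc2ccccc2c1C1C(C#N)=C(N)N(c2ccc(S(N)(=O)=O)cc2)C2=C1C(=O)CCC2`, has not yet been measured. It differs from compound 2 in one place: 2-methoxynaphthalen-1-yl in place of 2,4-dichlorophenyl on a saturated ring carbon. For the measured compounds named here, no measured step shows an aryl group of this kind at that carbon, so the single step from compound 1 to compound 2 is the only guide to how far a change of the aryl group can move the read-out in this assay. Since compound 2 already stands near the top of the scale, compound 3 is expected to fall somewhat lower, with a step of about a number 15 percentage points lower from compound 2 to compound 3 (beyond the scatter). The estimate for compound 3 in this assay is 80%, within 55% to 98%.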

Compound 3, a percentage reported as activity, at one concentration (the size of the read-out at that concentration, not a potency): 80%
The estimate for compound 3 equals the measured number at the digits printed; the range from low to high includes it.
By their numbers in this assay, from the lowest: compounds 1 and 3 (each within the scatter of the next); then compound 2.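

In this assay, a two-ring aryl group at this saturated ring carbon, 2-methoxynaphthalen-1-yl, gives a number 15 percentage points lower from compound 2 to compound 3 (beyond the scatter), so the 2,4-dichlorophenyl group is not matched by this larger group. Against the 3-nitrophenyl group the same change gives a number 9 percentage points higher from compound 1 to compound 3 (within the scatter), so these two aryl groups cannot be ordered, and among the three compounds only compound 2 stands apart from the others. Nothing available bears on the cause of these differences.

The compounds shown leave open whether the chlorine atoms or the single-ring aryl group carry the higher read-out, which an unsubstituted phenyl or a monochlorophenyl group at the same carbon would help to separate. Also open, from the compounds shown here alone, is how a pyridine ring, or an aryl group bearing an amine or a carboxylic acid, would behave there, and how the three compounds rank in potency rather than at one concentration.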